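The source may report more compounds than this note shows. Statements on the series, on what has been measured and on what is new or still open speak of the compounds shown alone.

Measured compounds in an ADME assay on MRC5 cells (Homo sapiens), read by MTT assay, with a stated time of 72 h; a lower number here means a stronger inhibitor, a higher number a weaker inhibitor:
compound 1, `Cc1ncnc2c1c(I)cn2[C@@H]1O[C@H](CO)[C@@H](O)[C@H]1O`, gives 13300 nM;
compound 2, `Cc1ncnc2c1c(-c1ccoc1)cn2[C@@H]1O[C@H](CO)[C@@H](O)[C@H]1O`, gives 98300 nM;
compound 3, `Cc1nc(N)c2c(I)cn([C@@H]3O[C@H](CO)[C@@H](O)[C@H]3O)c2n1`, gives 85800 nM.

Compound 1 and compound 2 share a core and differ by furan-3-yl in place of iodo on an aromatic carbon; this change gave a 7.4-fold higher number from compound 1 to compound 2 (0.87 log units; beyond the scatter). Compound 3 carries a different core; the difference between the two cores is not broken down here. In this assay compound 3 stands close to compound 2, and the two values lie within the scatter of each other, while compound 3 sits beyond the scatter from compound 1.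

Compound 4, `Cc1nc(N)c2c(-c3ccoc3)cn([C@@H]3O[C@H](CO)[C@@H](O)[C@H]3O)c2n1`, is not yet measured. It differs from compound 3 by furan-3-yl in place of iodo on an aromatic carbon, the same change as that from compound 1 to compound 2, made at the same place. Resting on the step from compound 1 to compound 2, a 7.4-fold higher number from compound 1 to compound 2 (0.87 log units; beyond the scatter), a step of similar direction and size is expected for compound 4, namely a 4.7-fold higher number from compound 3 to compound 4 (0.67 log units; beyond the scatter). Since compound 3 already gives 85800 nM, compound 4 is estimated to give 400000 nM, with a likely range from 100000 nM to 1500000 nM.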

Compound 4, half-maximal inhibitory concentration: > 100000 nM
Compound 4 ended at the assay's limit; the forecaster's own chance of this, stated with the estimate: 40%; the middle value is on the limit's open side.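

In this assay compound 4 gives > 100000 nM, which is a limit of the assay and not a number. Carried to the core of compound 3, furan-3-yl in place of iodo gives an at least 1.1-fold higher number from compound 3 to compound 4 (0.06 log units; that floor lies within the scatter). This is a floor and not a size, so the result is compatible with the step seen on the core of compound 1 but does not confirm that the step carries over, and whether the change is worth the same on both cores remains undecided: the same change on two cores in this assay, a 7.4-fold higher number (0.87 log units; beyond the scatter) from compound 1 to compound 2 and an at least 1.1-fold higher number (0.06 log units; that floor lies within the scatter) from compound 3 to compound 4; the limit leaves it open whether they differ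

The compounds shown leave open how the number would respond on either core to other groups on this aromatic carbon, such as an amine, a carboxylic acid or a longer alkyl chain. For the compounds shown here, with one change on only two cores, they also leave open whether the step would hold on any further core, and what number compound 4 would give if it could be read beyond the limit.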